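Two Tolerated Amides and a Methoxy Variant

The source may report more compounds than this note shows. Statements on the series, on what has been measured and on what is new or still open speak of the compounds shown alone.

compound 1: `COc1cccc(-c2cnc(NC(=O)c3ccc(F)cc3)n2C)c1` — > 100000 nM
compound 2: `COc1ccc(-c2cnc(NC(=O)c3ccccc3F)n2C)cc1` — > 100000 nM

In a toxicity assay on THP-1 cells (Homo sapiens) for inhibition (a higher number here means that more compound is tolerated, a lower number that less compound is tolerated), compound 1 gives > 100000 nM, which is a limit of the assay rather than a number. In this assay compound 2 likewise gives > 100000 nM, again a limit and not a number. Compound 2 therefore stands where every value shown stands, at the limit, as the limit of > 100000 nM in this assay, at which 2 of the 2 values shown sit, records. Compound 3 `COc1ccc(C(=O)Nc2ncc(-c3ccc(OC)cc3)n2C)cc1` is the next compound to be measured in this assay. It differs from compound 2 in one place: 4-methoxyphenyl in place of 2-fluorophenyl on a carbonyl carbon. Going by the values given here, no measured pair differs in a single place, so no measured step is available. Because both values shown sit at the limit described by the limit of > 100000 nM in this assay, at which 2 of the 2 values shown sit, the step is expected to be none beyond the scatter. Compound 3 is therefore estimated to give 100000 nM, within 50000 nM to 200000 nM, with a step of a number no higher from compound 2 to compound 3 (the limit leaves the size open) expected.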

Compound 3, half-maximal cytotoxic concentration: > 100000 nM
Compound 3: a limit, no number; the forecaster's own chance of this, stated with the estimate: 85%; the middle value lies on the limit itself.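

In this assay compound 3 gives > 100000 nM as a limit, not a number. No step can be read between compound 2 and compound 3, since both values are limits: the limit of > 100000 nM in this assay, at which 3 of the 3 values shown sit. The compounds shown leave open where any of them would give an actual number, and whether changing the group on the carbonyl carbon shifts it.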